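Fluoro in place of hydroxy on the weaker stereoisomer

The source may hold more compounds than are shown below. What is called first, only, known or untested is meant among the compounds shown, and "the series" means these compounds.

Compound 1 `Oc1ccc(-c2cn([C@H]3CN4CCC3CC4)nn2)cc1` gives the highest number of the three compounds measured in an assay on HEK293 cells for displacement of a labelled ligand from Neuronal acetylcholine receptor; alpha4/beta2 (Homo sapiens), read by scintillation counting, with a stated time of 120 min (a lower number here means a stronger inhibitor, a higher number a weaker inhibitor), namely 7390 nM. Its stereoisomer, compound 2 `Oc1ccc(-c2cn([C@@H]3CN4CCC3CC4)nn2)cc1`, gives 461 nM, and compound 3 `c1ccc(COc2cccc(-c3cn([C@@H]4CN5CCC4CC5)nn3)c2)cc1` gives 414 nM. Among the compounds with values here, the only single-change step measured is a 16-fold lower number from compound 1 to compound 2 (1.20 log units; beyond the scatter); the difference behind it is the fact that one of compounds 1 and 2 is drawn with a defined configuration and the other without, at the place where they differ. Compound 4 `Fc1ccc(-c2cn([C@H]3CN4CCC3CC4)nn2)cc1` differs from compound 1 by fluoro in place of hydroxy on an aromatic carbon. Within the data shown here, no measured step swaps hydroxy for fluoro: the step from compound 1 to compound 2 is a stereo change, and compound 3 differs from compound 1 in more than one place. The expected step is therefore small and uncertain, a rise in the number that may or may not pass the scatter: a 1.5-fold higher number from compound 1 to compound 4 (0.17 log units; within the scatter). Compound 4 is estimated at 11000 nM, with a range from 2500 nM to 40000 nM.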

Compound 4, inhibition constant: 10400 nM
For compound 4 the middle estimate is 1.1-fold (0.02 log units) above the measured one, within the range that was stated.
By their numbers in this assay, from the lowest: compounds 3 and 2 (each within the scatter of the next); then compounds 1 and 4 (each within the scatter of the next).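

In this assay, within the data shown here, the first measured change at this place, on an aromatic carbon para to a large group, gives a 1.4-fold higher number from compound 1 to compound 4 (0.15 log units; within the scatter). Hydroxy can therefore give way to fluoro, with hydrogen-bond donors going from 1 to 0 and acceptors from 1 to 0, without a step beyond the scatter in this stereoisomer. Nothing on hand accounts for the size of this step. The compounds shown leave open whether the same swap behaves alike in the configuration of compound 2. Going by these compounds, an amine or a carboxylic acid at this place also remains open.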